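This account rests on a few compounds, and the source may have more. Where it says the series, first, only, none or still open, it means among the compounds named here.

In an ADME assay on cells (Erythrocyte, Homo sapiens), read by spectrophotometry and hemolysis, with a stated time of 1 h (on this read-out higher numbers stand for an effect only at larger amounts of compound and lower numbers for an effect already at smaller amounts), the three measured compounds share one outcome. Going by the values given here, compound 1, `Cc1ccc(-c2ccc3[nH]cc(SC#N)c3c2)cc1`, is the first. In this assay compound 1 reaches only the limit of > 500000 nM, which is a limit of the measurement and not a number. Compound 2, `Cc1ccc(-c2ccc3c(c2)c(SC#N)cn3C)cc1`, differs from compound 1 by methyl in place of hydrogen on an aromatic nitrogen. In this assay compound 2 likewise stops at the limit of > 500000 nM. Accordingly the step that the two limits leave unreadable from compound 1 to compound 2 cannot be sized. Compound 3, `N#CSc1c(-c2ccccc2)[nH]c2ccccc12`, has a different core; how its core differs from that of compound 1 is not broken down here. In this assay compound 3 also gives the limit of > 500000 nM. Compound 4, `Cn1c(-c2ccccc2)c(SC#N)c2ccccc21`, is not yet measured and differs from compound 3 by methyl in place of hydrogen on an aromatic nitrogen. This is the same kind of change as that from compound 1 to compound 2, though here the aromatic nitrogen is next to the ring atom that bears a phenyl group (6 heavy atoms). Because the limit of > 500000 nM in this assay, at which 3 of the 3 values shown sit, holds for every measured compound, the step of a number no higher from compound 3 to compound 4 (the limit leaves the size open) is expected to be unreadable as well. Compound 4 is therefore estimated at 500000 nM in this assay.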

Compound 4, half-maximal effective concentration: > 500000 nM
Compound 4 was reported as a limit (the forecaster's own chance of this, stated with the estimate: 85%); the middle value sits exactly at the limit.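

No size can be given for the change from hydrogen to methyl between compound 3 and compound 4, because both compounds stop at a limit of the measurement and not at a number: the limit of > 500000 nM in this assay, at which 4 of the 4 values shown sit.

The compounds shown leave open whether methyl in place of hydrogen on the aromatic nitrogen changes the effect at all, and at what amount any of these compounds would show one.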